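This account rests on a few compounds, and the source may have more. Where it says the series, first, only, none or still open, it means among the compounds named here.

Measured compounds:
Compound 1 `CN(C)S(=O)(=O)c1ccccc1Nc1cc(-c2ccc3ccn(C)c3c2)c2nccnc2c1` gives 0.233 h.
Compound 2 `Cn1cc(CNC(=O)c2ccncc2Nc2cc(-c3ccc4ccn(C)c4c3)c3nccnc3c2)cn1` gives 0.267 h.

Both numbers come from an ADME assay on microsomes from liver (Mus musculus, strain CD-1) for metabolic stability, read by LC-MS, tested at 2 uM (a lower number here means that the compound disappears faster, a higher number that the compound lasts longer), in which compound 1 shows 0.233 h and compound 2 shows 0.267 h. The gap between compound 2 and compound 1 lies within the usual scatter of this assay, so the two compounds cannot be told apart on these numbers, and both show a short half-life. For the measured compounds named here, no pair of measured compounds differs in a single place, so nothing here shows directly how one change moves the half-life.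

Compound 3 `CC(=O)N1CCC(NC(=O)c2ccncc2Nc2cc(-c3ccc4ccn(C)c4c3)c3nccnc3c2)C1` has not yet been measured. It differs from compound 2 in one place: 1-acetylpyrrolidin-3-yl in place of (1-methyl-1H-pyrazol-4-yl)methyl on an amide-type nitrogen. The shared core of compound 2 and compound 3 is kept, as is the carbonyl carbon that neighbours the amide-type nitrogen carrying the changed group. Going by the values given here, with no single-change step among the measured compounds to draw on, the step expected in this assay is small: a 1.1-fold higher number from compound 2 to compound 3 (0.05 log units; within the scatter) is expected to stay within the scatter, with no clear direction. Compound 3 is therefore estimated at 0.3 h, with a range from 0.15 h to 0.6 h.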

Compound 3, half-life: 0.667 h
Estimate against measurement, compound 3: 2.2-fold (0.35 log units) below; the measured number lies above the stated range.
By their numbers in this assay, from the lowest: compounds 1 and 2 (each within the scatter of the next); then compound 3.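

In this assay, for the compounds shown here, the amide-type nitrogen proves to be a place where the half-life responds to the group it carries: 1-acetylpyrrolidin-3-yl in place of (1-methyl-1H-pyrazol-4-yl)methyl gives a 2.5-fold higher number from compound 2 to compound 3 (0.40 log units; beyond the scatter) and is the only step so far between measured compounds that differ in one place. The change exchanges one five-membered aromatic ring with 2 hetero atoms for one five-membered non-aromatic ring with 1 hetero atom, and the entering group also brings a double bond outside aromatic rings, while the shared core stays the same. No measurement is available that would explain the step.

The compounds shown leave open which part of the entering group goes with the higher number, the acetyl or the non-aromatic ring, and a pyrrolidin-3-yl carrying a free amine in place of the acetylated nitrogen would help separate the two. Also open, on these data alone, is how far the half-life moves with other groups on this nitrogen, such as a longer alkyl chain or a chain ending in a carboxylic acid.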